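A Long Chain Gives Way to an Aromatic Ring

The compounds below may be only part of what the source reports. "The series", "measured", "known", "first", "only" and "open" are said of these compounds alone.

Of the compounds shown here, three sharing one core have been tested in an ADME assay on HEL cells (Homo sapiens) for cytotoxicity, with a stated time of 3 days; on this read-out lower numbers stand for higher toxicity in this test and higher numbers for lower toxicity in this test. Among the compounds with values here, compound 1 `CCCCCCCC/C=C/c1cc2cn([C@H]3C[C@H](O)[C@@H](CO)O3)c(=O)nc2o1` gives 230000 nM, the only exact number in this small set. Compound 2 `CCCCCCCCCCc1cc2cn([C@H]3C[C@H](O)[C@@H](CO)O3)c(=O)nc2o1` is reported as > 510000 nM, which is a limit and not a number. Compound 3 `CCCc1ccc(C#Cc2cc3cn([C@H]4C[C@H](O)[C@@H](CO)O4)c(=O)nc3o2)cc1` is reported as > 120000 nM, and this is also a limit. Compound 2 therefore has no exact position on the scale.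

Compound 4 `Cc1ccc(CCc2cc3cn([C@H]4C[C@H](O)[C@@H](CO)O4)c(=O)nc3o2)cc1` has not yet been measured. Its structure departs from that of compound 2 in one place: 4-methylphenyl in place of octyl on a saturated chain carbon, two bonds along the chain from an aromatic carbon. Put simply, 4-methylphenyl stands in place of octyl on a saturated chain carbon, two bonds along the chain from an aromatic carbon.

The expected step in this assay is an at least 2.3-fold lower number from compound 2 to compound 4 (0.36 log units; beyond the scatter), a moderate move towards lower numbers. Within the data shown here, this expectation leans on compound 1, whose 230000 nM is the one exact reading available. For compound 4 the estimated value is 220000 nM, with an expected range of 70000 nM to 540000 nM.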

Compound 4, half-maximal cytotoxic concentration: > 540000 nM
Compound 4 was reported as a limit (the forecaster's own chance of this, stated with the estimate: 60%); at least 2.4-fold (0.38 log units) between middle value and limit.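

Compound 2 and compound 4 are both reported only as limits and not as numbers, and the step between them cannot be read. The compounds shown leave open whether 4-methylphenyl in place of octyl moves the cytotoxicity reading at all, and by how much.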